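The compounds below may be only part of what the source reports. "The series", "measured", "known", "first", "only" and "open" are said of these compounds alone.

Measured compounds:
compound 1, `COC(=O)c1ccccc1-c1cnc(C(=O)CCCCCCc2ccccc2)o1`, 60 nM
compound 2, `O=C(CCCCCCc1ccccc1)c1ncc(-c2ccccc2C(=O)C(F)(F)F)o1`, 5000 nM
compound 3, `NC(=O)c1cccc(-c2cnc(C(=O)CCCCCCc3ccccc3)o2)c1`, 6 nM

The read-out throughout is an assay (Rattus norvegicus) for inhibition of Fatty-acid amide hydrolase 1 (Homo sapiens); on this read-out lower numbers stand for stronger inhibition and higher numbers for weaker inhibition. Among the three measured compounds, compound 3 gives the lowest number, with 6 nM; the nearest is compound 1 at 60 nM, and the furthest is compound 2 at 5000 nM, so compound 3 is the strongest inhibitor of the set on this read-out.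

The unmeasured compound 4, `Cc1cccc(-c2cnc(C(=O)CCCCCCc3ccccc3)o2)n1`, differs from compound 3 in the group attached to the shared core: 6-methylpyridin-2-yl in place of 3-carbamoylphenyl on an aromatic carbon.

Among the measured compounds shown here, the only step measured in a single place is an 83-fold higher number from compound 1 to compound 2 (1.92 log units; beyond the scatter), where the change sits on a carbonyl carbon of a substituent rather than replacing the whole ring that carries it. It does not bear directly on the change from compound 3 to compound 4. Compound 1 and compound 3 show that a carbamoyl group on the ring goes with a lower number than a methoxycarbonyl group, but they differ in more than one place, so no single step can be read from them. For the measured compounds named here, with no step that matches this change, the expectation rests loosely on the spread of the measured numbers: compound 4 is expected to lose ground against compound 3, with a step of about an 8.3-fold higher number from compound 3 to compound 4 (0.92 log units; beyond the scatter), landing near compound 1. The estimate for compound 4 is 50 nM, with a range from 10 nM to 300 nM.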

Compound 4, inhibition constant: 3.3 nM
Estimate against measurement, compound 4: 15-fold (1.18 log units) above; the whole stated range lies above it.
By their numbers in this assay, from the lowest: compounds 4 and 3 (each within the scatter of the next); then compound 1; then compound 2.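

In this assay, the step on the aromatic carbon next to the ring oxygen, with 6-methylpyridin-2-yl in place of 3-carbamoylphenyl, is a 1.8-fold lower number from compound 3 to compound 4 (0.26 log units; within the scatter), so on this read-out the two groups cannot be told apart. The earlier compounds shown here gave no single-place step at this position, and this pair shows that a value of this order does not depend on the carbamoyl group: the entering group has 0 hydrogen-bond donors where the leaving group has 1, and its six-membered aromatic ring has 1 hetero atom where the other has carbon only. No independent measurement bears on why the two groups match.

The methyl group and the ring nitrogen enter together in this one step, so the compounds shown leave open what each of them contributes, and a plain pyridin-2-yl or a 3-methylphenyl would be needed to separate the two. Going by these compounds, it also remains open whether a carboxylic acid or an amine on this ring would stay level with these two compounds, or whether the match would hold with a shorter chain on the carbonyl.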